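Trifluoromethyl to methylsulfanyl on the shared core

The compounds below may be only part of what the source reports. "The series", "measured", "known", "first", "only" and "open" are said of these compounds alone.

In a functional assay on U-251 cells (Homo sapiens) for cytotoxicity (a lower number here means a stronger inhibitor of growth, a higher number a weaker inhibitor of growth), compound 1 (`COc1ccc(C2=C(c3ccc(SC)cc3)CC3CCCN3C2=O)cc1C`) gives 90 nM and compound 2 (`CSc1ccc(C2=C(c3ccc(O)c(O)c3)C(=O)N3CCCC3C2)cc1`) gives 30000 nM. Compound 3 (`CSc1ccc(C2=C(c3ccc(C(F)(F)F)cc3)C(=O)N3CCCC3C2)cc1`) gives 800 nM, the middle of these three numbers. Compound 4 (`CSc1ccc(C2=C(c3ccc(SC)cc3)C(=O)N3CCCC3C2)cc1`) is not yet measured. It differs from compound 3 by methylsulfanyl in place of trifluoromethyl on an aromatic carbon.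

Among the measured compounds shown here, the only measured step, a 330-fold higher number from compound 1 to compound 2 (2.52 log units; beyond the scatter), is large and beyond the scatter. It exchanges the aryl group on the same double-bonded ring carbon, so a change at this group may well shift the number. That step does not involve either group now in question, so it gives no direct size for this change. For the measured compounds named here, the expected direction is a judgement that rests on compound 1 at 90 nM, the lowest number so far, and assumes compound 4 falls nearer to it. The expected change is a moderate one, a 4.0-fold lower number from compound 3 to compound 4 (0.60 log units; beyond the scatter), towards stronger growth inhibition. For compound 4 the estimated value is 200 nM, with an expected range of 50 nM to 800 nM.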

Compound 4, concentration for 50% growth inhibition: 5000 nM
Beside the measured number, compound 4's estimate is 25-fold (1.40 log units) below it; measured number outside the range, above it.
By their numbers in this assay, from the lowest: compound 1; then compound 3; then compound 4; then compound 2.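

In this assay, methylsulfanyl in place of trifluoromethyl on this aromatic carbon gives a 6.3-fold higher number from compound 3 to compound 4 (0.80 log units; beyond the scatter) and so moves the number upward, towards weaker growth inhibition. Set against the other aryl groups on the same double-bonded ring carbon, the 4-(methylsulfanyl)phenyl of compound 4 gives a 56-fold higher number from compound 1 to compound 4 (1.74 log units; beyond the scatter) and also a 6.0-fold lower number from compound 2 to compound 4 (0.78 log units; beyond the scatter) in the second comparison. The four aryl groups now form an order at this carbon, with 4-methoxy-3-methylphenyl lowest, then 4-(trifluoromethyl)phenyl, 4-(methylsulfanyl)phenyl and 3,4-dihydroxyphenyl.

Nothing measured on these compounds accounts for that order. Going by these compounds, whether an amine or a carboxylic acid on this aromatic carbon would give a number nearer that of compound 1 or that of compound 2 remains open.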